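Dropping One Chloro From a Weakly Binding Amide

This account rests on a few compounds, and the source may have more. Where it says the series, first, only, none or still open, it means among the compounds named here.

Compound 1 `O=C(CCCc1ccc(Cl)c(Cl)c1)Nc1nc2ccccc2c(=O)s1` is tested in an assay on CHO cells for displacement of a labelled ligand from adenosine receptor A3 (Homo sapiens), read by scintillation counting, with a stated time of 60 min; on this read-out higher numbers stand for weaker inhibition and lower numbers for stronger inhibition. In this assay compound 1 gives only a limit, > 1000 nM. Compound 2 `O=C(COc1cccc(Cl)c1)Nc1nc2ccccc2c(=O)s1` likewise returns only a limit in this assay, > 1000 nM. Both results therefore sit together at the limit of > 1000 nM in this assay, at which 2 of the 2 values shown sit, so compound 1 stands at the edge of what this assay can report. Compound 3 `O=C(CCCc1cccc(Cl)c1)Nc1nc2ccccc2c(=O)s1` differs from compound 1 by hydrogen in place of chloro on an aromatic carbon. Within the data shown here, with no measured step to guide it, the change is expected to shift this assay by no more than the scatter, a step that the limit leaves unreadable from compound 1 to compound 3. Compound 3 is thus estimated at 3000 nM, between 1000 nM and 10000 nM.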

Compound 3, inhibition constant: > 1000 nM
Compound 3 ended at the assay's limit (the forecaster's own chance of this, stated with the estimate: 80%); the middle value is on the limit's open side.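

Among these compounds, compound 1 and compound 3 both stand only as limits of the assay, so no step between them can be read. The compounds shown leave open whether hydrogen in place of chloro shifts the result in this assay at all, and where any of the three truly lies.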